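The compounds below may be only part of what the source reports. "The series", "measured", "known", "first", "only" and "open" are said of these compounds alone.

For the measured compounds named here, compound 2, `COc1ccc(-c2cc3ccccc3nc2/C=C/C(=O)c2ccc(OC)cc2OC)cc1`, is one of two compounds measured so far in a functional assay on MCF7 cells (Homo sapiens) for antiproliferative activity, read by XTT assay, with a stated time of 72 h; on this read-out lower numbers stand for stronger inhibition and higher numbers for weaker inhibition. Compound 2 gives 6260 nM, and compound 1, `COc1ccc(-c2cc3ccccc3nc2/C=C/C(=O)c2ccc(O)cc2)cc1`, gives 6710 nM; the two numbers lie within the scatter of each other, so neither can be told apart from the other. Compound 3, `COc1ccc(-c2cc3ccccc3nc2/C=C/C(=O)c2ccc(N)cc2)cc1`, has not been measured; it differs from compound 2 in that (4-aminophenyl in place of 2,4-dimethoxyphenyl on a carbonyl carbon). Going by the values given here, the only measured step that speaks to this position is a 1.1-fold lower number from compound 1 to compound 2 (0.03 log units; within the scatter), where the group on the same carbonyl carbon was exchanged with no change beyond the scatter. The 4-aminophenyl entering in compound 3 carries one hydrogen-bond donor and one acceptor, as did the 4-hydroxyphenyl of compound 1. Among the compounds with values here, with only this one step to go on, the expected change in this assay is a 1.0-fold higher number from compound 2 to compound 3 (0.02 log units; within the scatter), that is none beyond the scatter. Compound 3 is therefore estimated at 6500 nM, with a range from 2500 nM to 17000 nM.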

Compound 3, half-maximal inhibitory concentration: 6920 nM
Compound 3: the middle estimate sits 1.1-fold (0.03 log units) below what was measured, and the stated range covers the measured number.
By their numbers in this assay, from the lowest: compounds 2, 1 and 3 (each within the scatter of the next).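

Replacing 2,4-dimethoxyphenyl with 4-aminophenyl on the carbonyl carbon gives a 1.1-fold higher number from compound 2 to compound 3 (0.04 log units; within the scatter) in this assay, so this second exchange at the position also stays inside the scatter. The swap of amino for hydroxy on an aromatic carbon gives a 1.0-fold higher number from compound 1 to compound 3 (0.01 log units; within the scatter), which adds a direct comparison of those two groups and likewise separates nothing, so the three aryl groups on this carbonyl carbon cannot be told apart here. No evidence is available that would explain this result.

The compounds shown leave open whether any group at this position can shift the number beyond the scatter. A carboxylic acid or a longer chain in place of the amino group would be a much sharper test of that question.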